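Swapping a fluorophenyl for a styryl arm on a shared core

The source may hold more compounds than are shown below. What is called first, only, known or untested is meant among the compounds shown, and "the series" means these compounds.

Of the compounds shown here, two with a shared core have been tested in an ADME assay on HepG2 cells (Homo sapiens) for cytotoxicity, read by MTT assay, with a stated time of 72 h; a lower number here means that less compound is tolerated, a higher number that more compound is tolerated. Compound 1 `Nc1sc2c(c1-c1nc3cc(Cl)ccc3s1)CCCC2` carries a free amino group and a chlorine on one ring; in this assay compound 1 gives 93.7 ug/mL. Compound 2 `Fc1ccc(/C=N/c2sc3c(c2-c2nc4ccccc4s2)CCCC3)cc1` instead carries a 4-fluorophenyl group joined through a carbon with a double bond to nitrogen, and in this assay compound 2 gives 324 ug/mL, the higher of the two numbers, with a gap to compound 1 that lies beyond the usual scatter.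

Compound 3 `C(=C/c1ccccc1)\C=N\c1sc2c(c1-c1nc3ccccc3s1)CCCC2` is the next step: 2-phenylethenyl in place of 4-fluorophenyl on a carbon with a double bond to nitrogen. Within the data shown here, no measured pair shows what such a change does here, so the expectation is a step that stays within the scatter, in no firm direction. The expected step is a 1.1-fold lower number from compound 2 to compound 3 (0.03 log units; within the scatter). For compound 3 the estimated value is 300 ug/mL, with a range from 150 ug/mL to 600 ug/mL.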

Compound 3, half-maximal cytotoxic concentration: 467 ug/mL
Beside the measured number, compound 3's estimate is 1.6-fold (0.19 log units) below it; low and high end bracket the measured number.
By their numbers in this assay, from the lowest: compound 1; then compounds 2 and 3 (each within the scatter of the next).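

On a carbon with a double bond to nitrogen, putting 2-phenylethenyl in place of 4-fluorophenyl gives a 1.4-fold higher number from compound 2 to compound 3 (0.16 log units; within the scatter) in this assay. This is the first pair shown that differs in one place only, and it shows that here the fluorine can leave and a double bond outside the aromatic ring can enter without the number moving past the usual scatter. Nothing measured here explains why these two groups read alike.

Still open, as far as these compounds go, is whether the same holds for a group of another kind at this place, such as an amine, a carboxylic acid or a longer saturated chain. A plain phenyl group would also show how compound 2 and compound 3 compare with an arm that has neither the fluorine nor the extra double bond.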